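The compounds below may be only part of what the source reports. "The series", "measured", "known", "first", "only" and "open" are said of these compounds alone.

Measured in a functional assay on Gurav cells (Homo sapiens) for inhibition, read by sulforhodamine B assay; on this read-out lower numbers stand for stronger inhibition of growth and higher numbers for weaker inhibition of growth:
- Compound 1 `COc1cc(-c2ccc(-c3ccc(-c4nc5cc(C)ccc5[nH]4)cc3)cc2)cc(OC)c1OC`: 170 nM
- Compound 2 `COc1ccc(-c2ccc(-c3ccc(-c4nc5ccccc5[nH]4)cc3)cc2)cc1OC`: 9230 nM

Of these two numbers, compound 2 has the higher, and its gap to compound 1 lies beyond the scatter. Not yet measured is compound 3 `COc1cc(-c2ccc(-c3ccc(-c4nc5ccccc5[nH]4)cc3)cc2)cc(OC)c1OC`, which differs from compound 2 by methoxy in place of hydrogen on an aromatic carbon. Methoxy replaces hydrogen on an aromatic carbon, ortho to a methoxy group and meta to a large group.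

Within the data shown here, no measured pair isolates this change, so its size can only be inferred. In this assay, a large move to a lower number, beyond the scatter, is expected. The main guide is compound 1 at 170 nM, which also holds the entering methoxy. The estimated change is a 21-fold lower number from compound 2 to compound 3 (1.31 log units; beyond the scatter). The expected value for compound 3 is 450 nM, with an estimated range of 120 nM to 2500 nM.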

Compound 3, concentration for 50% growth inhibition: 7100 nM
Compound 3: the middle estimate sits 16-fold (1.20 log units) below what was measured, outside the stated range (above it).
By their numbers in this assay, from the lowest: compound 1; then compounds 3 and 2 (each within the scatter of the next).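

In this assay, methoxy in place of hydrogen on this aromatic carbon, ortho to a methoxy group, does not separate the two compounds: a 1.3-fold lower number from compound 2 to compound 3 (0.11 log units; within the scatter). The large step lies at the other place, on a different aromatic carbon, with hydrogen in place of methyl: a 42-fold higher number from compound 1 to compound 3 (1.62 log units; beyond the scatter), which leaves compound 1 alone at the low end of this set and shows that the methoxy is not what sets it apart from compound 3. Nothing available bears on why the two steps differ so much in size.

Open, as far as these compounds go, is whether the methyl step holds on the core of compound 2, which carries one methoxy fewer. Also open, from the compounds shown here alone, is whether an ethyl, a chlorine or an amine on that same aromatic carbon gives a step of similar size.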